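The source may report more compounds than this note shows. Statements on the series, on what has been measured and on what is new or still open speak of the compounds shown alone.

Measured compounds:
- compound 1, `COc1cc(/C=C/C(=O)CC(=O)/C=C/c2ccc(OC(=O)C(C)c3ccc(C(=O)c4ccccc4)cc3)c(OC)c2)ccc1O`: 8980 nM
- compound 2, `COc1cc(/C=C/C(=O)CC(=O)/C=C/c2ccc(OC(=O)c3ccccc3OC(C)=O)c(OC)c2)ccc1O`: > 30000 nM

Two esters of the same shared core have been tested in a functional assay on RAW264.7 cells (Mus musculus) for inhibition; a lower number here means a stronger inhibitor, a higher number a weaker inhibitor. Compound 1 gives 8980 nM in this assay, a measured number. For compound 2 this assay reports only a limit, > 30000 nM, so compound 2 stands at the weak edge of what the assay can resolve; this is the situation described by the limit of > 30000 nM in this assay, at which 1 of the 2 values shown sits. Nothing more can be read from compound 2 than that it lies at that limit.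

Compound 3, `COc1cc(/C=C/C(=O)CC(=O)/C=C/c2ccc(OC(=O)C(C)c3ccc(CC(C)C)cc3)c(OC)c2)ccc1O`, has not yet been measured. It differs from compound 2 in one place: 1-(4-isobutylphenyl)ethyl in place of 2-acetoxyphenyl on a carbonyl carbon. The group that enters resembles the aryl-propanoyl ester side of compound 1 more than the 2-acetoxyphenyl of compound 2 does, and compound 1 reached a measured value in this assay. A step toward stronger inhibition is therefore expected, estimated as an at least 3.3-fold lower number from compound 2 to compound 3 (0.52 log units; beyond the scatter), moving compound 3 off the limit. Compound 3 is expected to give about 9000 nM in this assay, within a range of 3000 nM to 30000 nM.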

Compound 3, half-maximal inhibitory concentration: > 30000 nM
Compound 3: no number, only a limit; the forecaster's own chance of this, stated with the estimate: 25%; middle value at least 3.3-fold (0.52 log units) away from the limit.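

On the aryl-propanoyl ester, the change from benzoyl to isobutyl on an aromatic carbon weakens inhibition in this assay, giving an at least 3.3-fold higher number from compound 1 to compound 3 (0.52 log units; beyond the scatter). This shows that the aryl-propanoyl ester does not reach a measured value on its own: with this pair, the result depends on what sits on that aromatic carbon, and here benzoyl gives a measured value while isobutyl does not. The step between compound 2 and compound 3 cannot be read, and the comparison of their ester groups stays closed, as both compounds sit at the same limit of the assay: the limit of > 30000 nM in this assay, at which 2 of the 3 values shown sit.

As far as these compounds go, how far compound 3 lies beyond that limit remains open, so the true size of its step from compound 1 is unknown, and any difference between compound 2 and compound 3 is hidden. Also open, from the compounds shown here alone, is whether benzoyl is specifically needed, which other groups on that aromatic carbon, such as an amine, a carboxylic acid or a longer chain, could help to settle.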